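Two chlorines on the benzyl group of compound 2

A few compounds are considered here, and "the series" means these few. Any claim that something is new, unique, unknown or untested is made for them only; others in the source may bear on it.

Compound 2 `Cc1ccc(C(=O)NO)cc1NC(=O)c1cccc(OCc2ccccc2)c1` shares its core with compound 1 `COc1ccc(C(=O)NO)cc1NC(=O)c1cccc(OCc2ccccc2)c1`; the two differ only by methyl in place of methoxy on an aromatic carbon. In an assay on isolated protein for inhibition of histone deacetylase 8 (Homo sapiens), read by fluorescence, with a stated time of 90 min, tested at 1 uM (a lower number here means less inhibition, a higher number more inhibition at the concentration tested (going by the name of the read-out)), compound 1 gives 59%, and compound 2 gives 60%. The step of a number 1 percentage points higher from compound 1 to compound 2 (within the scatter) is small, so the two numbers sit within the scatter of each other and neither compound can be placed ahead of the other. Compound 3 `Cc1ccc(C(=O)NO)cc1NC(=O)c1cccc(OCc2c(Cl)cccc2Cl)c1` keeps the methyl group of compound 2 and alters the far end of the molecule: 2,6-dichlorophenyl in place of phenyl on a saturated chain carbon bound to an oxygen on an aromatic ring. Cut one bond further out, the benzyloxy group of compound 2 becomes (2,6-dichlorobenzyl)oxy. For the measured compounds named here, no measured step touches this part of the molecule; the single step in hand, a number 1 percentage points higher from compound 1 to compound 2 (within the scatter), concerns a different position and offers no guide to adding two chlorines to the benzyl group. The account therefore expects compound 3 to remain close to compound 2, with an expected step of no change at the digits printed from compound 2 to compound 3 (within the scatter) and no direction claimed beyond the scatter. In this assay compound 3 is estimated at 60%, within a range of 40% to 80%.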

Compound 3, a percentage reported as inhibition, at one concentration (the size of the read-out at that concentration, not a potency): 34%
Compound 3: middle estimate off by 26 percentage points, on the high side; measured number below the stated range.
By their numbers in this assay, from the lowest: compound 3; then compounds 1 and 2 (each within the scatter of the next).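

For the compounds shown here, the far end of the molecule matters in this assay: 2,6-dichlorophenyl in place of phenyl on a saturated chain carbon bound to an oxygen on an aromatic ring gives a number 26 percentage points lower from compound 2 to compound 3 (beyond the scatter) and so lies beyond the scatter, whereas the only earlier step, methyl in place of methoxy, did not. This position therefore responds to substitution in a way the earlier pair gave no sign of, with the two added chlorines on the benzyl group going with less inhibition at the concentration tested, a size of read-out and not a potency. Nothing available accounts for this drop, and no measurement of any property of these groups bears on it.

Going by these compounds, whether a single chlorine, a fluorine or an amine on the benzyl group would shift the number in the same way remains open, as does the outcome of a longer chain in place of the benzyl group. On these data alone, it is also open whether the 2,6-dichlorobenzyl group would give a step of similar size on the core of compound 1, which carries methoxy in place of methyl.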